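This account rests on a few compounds, and the source may have more. Where it says the series, first, only, none or still open, it means among the compounds named here.

In a physicochemical assay, with a stated time of 90 min (on this read-out higher numbers stand for an effect only at larger amounts of compound and lower numbers for an effect already at smaller amounts), compound 1 (`C/C(=N\N=C1/SCC(=O)N1Cc1cccc(Cl)c1)c1ccccn1`) gives 2040000 nM as its reading and compound 2 (`O=C1CS/C(=N\N=C2CCCC2)N1Cc1ccccc1F`) gives 700000 nM as its reading. Compound 2 holds the lower of the two numbers, and the gap to compound 1 lies beyond the scatter. Compound 3 (`O=C1CS/C(=N\N=C2CCCC2)N1Cc1ccc(Cl)cc1`) is still unmeasured and differs from compound 2 in one place (4-chlorophenyl in place of 2-fluorophenyl on a saturated chain carbon bound to an amide-type nitrogen in a ring). It carries 4-chlorophenyl in place of 2-fluorophenyl on a saturated chain carbon bound to an amide-type nitrogen in a ring. Going by the values given here, no measured pair yet differs in one place, so no measured step sizes this exchange. In this assay no change beyond the scatter is expected, with a slight rise as the likelier direction. The estimated step is a 1.3-fold higher number from compound 2 to compound 3 (0.11 log units; within the scatter) and stays within the scatter. Compound 3 is estimated at 900000 nM with an expected range from 300000 nM to 2700000 nM around that middle.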

Compound 3, half-maximal effective concentration: 560000 nM
Estimate against measurement, compound 3: 1.6-fold (0.21 log units) above; the range from low to high includes it.
By their numbers in this assay, from the lowest: compounds 3 and 2 (each within the scatter of the next); then compound 1.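

In this assay, going by these compounds alone, the first pair of the series that differs in one place gives a 1.3-fold lower number from compound 2 to compound 3 (0.10 log units; within the scatter). On a saturated chain carbon bound to an amide-type nitrogen in a ring, 4-chlorophenyl in place of 2-fluorophenyl therefore leaves the read-out unchanged within the scatter, so at this place on the shared core one halogen-bearing phenyl reads like the other. No supporting data bear on why the two groups read alike.

On these data alone, the exchange alters the halogen and its place on the phenyl together, so the contribution of each remains open. Also open, as far as these compounds go, is how this place responds to a group of another kind, such as a phenyl carrying a carboxylic acid or an amine, or a longer chain in place of the phenyl.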